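The source may report more compounds than this note shows. Statements on the series, on what has been measured and on what is new or still open speak of the compounds shown alone.

Compound 1 `O=C(OCc1ccccc1)c1coc(-c2ccccc2)n1`, compound 2 `O=C(OCc1ccccc1C(F)(F)F)c1coc(-c2ccccc2)n1` and compound 3 `O=C(Oc1cccc(C(F)(F)F)c1)c1coc(-c2ccccc2)n1` share a common core and differ in the ester part. In an ADME assay on microsomes from liver (Rattus norvegicus, strain Sprague-Dawley) for metabolic stability, read by LC-MS, with a stated time of 15 min, tested at 20 uM (a lower number here means that less of the compound is left, a higher number that more of the compound is left), compound 1 gives 2.7%, compound 2 gives 7.8% and compound 3 gives 13%. The difference between the cores of compound 2 and compound 3 is not broken down here. The step of a number 5.1 percentage points lower from compound 2 to compound 1 (within the scatter) accompanied the change (hydrogen in place of trifluoromethyl on an aromatic carbon), placed ortho to a large group. Compound 4 `O=C(Oc1ccccc1)c1coc(-c2ccccc2)n1` has not been measured yet; it arises from compound 3 by hydrogen in place of trifluoromethyl on an aromatic carbon, the same kind of change, here placed meta to a large group. Because compound 3 gives 13% and the earlier step was within the scatter, a small step of a number 5 percentage points lower from compound 3 to compound 4 (within the scatter) is expected. For compound 4 in this assay the estimate is 8%, expected to lie between 2% and 16%.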

Compound 4, percent of the compound remaining in the Rattus norvegicus assay: 0.2%
Beside the measured number, compound 4's estimate is 7.8 percentage points above it; measured number outside the range, below it.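

In the Rattus norvegicus assay, compound 3 gives 13%, compound 1 gives 2.7% and compound 4 gives 0.2%; putting hydrogen in place of trifluoromethyl gives a number 12.8 percentage points lower from compound 3 to compound 4 (beyond the scatter) and putting phenyl in place of benzyl on the ester oxygen gives a number 2.5 percentage points lower from compound 1 to compound 4 (within the scatter). The hydrogen-for-trifluoromethyl change can be compared on two cores, and its two steps do not differ beyond the scatter: the same change on two cores in the Rattus norvegicus assay, a number 5.1 percentage points lower (within the scatter) from compound 2 to compound 1 and a number 12.8 percentage points lower (beyond the scatter) from compound 3 to compound 4, 7.7 percentage points apart, within the scatter of two such steps. Going by these compounds alone, this fits the change carrying over between these two cores, but with only one of the steps beyond the scatter and only two cores compared, it shows no general rule and no reliable size for the step. In a physicochemical assay for metabolic stability, read by LC-MS, in simulated gastric fluid, with a stated time of 15 min, tested at 50 uM (a lower number here means that less of the compound is left, a higher number that more of the compound is left), compound 3 gives 5.5% and compound 4 gives 0.2%. In the physicochemical assay the same change gives a number 5.3 percentage points lower from compound 3 to compound 4 (within the scatter).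

The compounds shown leave open how a chlorine atom, a methoxy group or a nitrile in place of trifluoromethyl would behave. They also leave open whether an amide in place of the ester would leave more compound.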